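This account rests on a few compounds, and the source may have more. Where it says the series, first, only, none or still open, it means among the compounds named here.

Of the compounds shown here, three have been measured in a functional assay (blood) for inhibition, with Homo sapiens as the target; a higher number here means a weaker inhibitor, a lower number a stronger inhibitor. Compound 1, `OC1O[C@H](CO/N=C2\CCc3cc(Sc4cc(F)cc(C5CCOCC5)c4)ccc32)[C@H](O)[C@H](O)[C@H]1O`, sits at the assay limit; in this assay compound 1 gives > 2500 nM. Compound 2, `CO[C@]1(c2cc(F)cc(S(=O)(=O)c3ccc(/C(C)=N/O)cc3)c2)CCO[C@@H](C)C1`, gives 20 nM in this assay. Compound 3, `CCOC(=O)/C(=N\O)c1ccc(Sc2cc(F)cc(C3CCOCC3)c2)cc1`, gives 170 nM in this assay, the highest of the two numbers; compound 2 is the nearest, with a lower value that lies beyond the scatter.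

Compound 4, `CS/C(=N\O)c1ccc(Sc2cc(F)cc(C3CCOCC3)c2)cc1`, differs from compound 3 in one place: methylsulfanyl in place of ethoxycarbonyl on a carbon with a double bond to nitrogen. Going by the values given here, no measured pair shows such a change. Compound 4 is expected to sit modestly lower than compound 3, with an estimated step of a 1.7-fold lower number from compound 3 to compound 4 (0.23 log units; within the scatter) that may still fall within the scatter. Compound 4 is therefore estimated at 100 nM, within a range from 25 nM to 400 nM.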

Compound 4, half-maximal inhibitory concentration: 190 nM
Compound 4: middle estimate off by 1.9-fold (0.28 log units), on the low side, and the stated range covers the measured number.
By their numbers in this assay, from the lowest: compound 2; then compounds 3 and 4 (each within the scatter of the next). At a limit, above all of these: compound 1.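

On the carbon with a double bond to nitrogen, methylsulfanyl in place of ethoxycarbonyl gives a 1.1-fold higher number from compound 3 to compound 4 (0.05 log units; within the scatter) in this assay. At this position, the two groups read alike, although ethoxycarbonyl counts 5 heavy atoms and methylsulfanyl 2. No measured property shown bears on why these two values match.

As far as these compounds go, whether a carboxylic acid or an amine on this carbon would read the same remains open. So does whether this match would hold on a different core.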